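The compounds below may be only part of what the source reports. "The series", "measured", "known", "first", "only" and "open" are said of these compounds alone.

Compound 1 `CC(C)S(=O)(=O)NC1CCCN(S(=O)(=O)c2ccc(F)cc2)C1` is one of three compounds examined in a functional assay on the whole organism with Mus musculus as the target, with a stated time of 30 min; on this read-out higher numbers stand for an effect only at larger amounts of compound and lower numbers for an effect already at smaller amounts. In this assay compound 1 gives 1 mg/kg, and compound 3 `O=S(=O)(NCC1CCN(S(=O)(=O)c2ccc(F)cc2)CC1)c1ccc(F)cc1` gives 1 mg/kg, a number level with that of compound 1 within the scatter, so the two stand together at the top of the set. Compound 2 `CC(=O)N1CCN(S(=O)(=O)c2ccc(F)cc2)CC1` gives 0.01 mg/kg, a far lower number that lies well beyond the scatter from compound 1. Compound 4 `CCC(=O)NC1CCCN(S(=O)(=O)c2ccc(F)cc2)C1` has not yet been measured; it differs from compound 1 by propanoyl in place of isopropylsulfonyl on an amine nitrogen. Going by the values given here, no measured pair isolates this change, and compound 2 at 0.01 mg/kg shows only that far lower numbers occur on this core. Compound 4 is expected to move modestly toward a lower number, a step of a 3.3-fold lower number from compound 1 to compound 4 (0.52 log units; beyond the scatter). The estimate for compound 4 is 0.3 mg/kg, with a range from 0.03 mg/kg to 1 mg/kg.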

Compound 4, minimum effective dose: 1 mg/kg
Compound 4: middle estimate off by 3.3-fold (0.52 log units), on the low side, and the stated range covers the measured number.
By their numbers in this assay, from the lowest: compound 2; then compounds 1, 3 and 4 (each within the scatter of the next).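

In this assay, going by these compounds alone, putting propanoyl in place of isopropylsulfonyl on the amine nitrogen gives no change at the digits printed from compound 1 to compound 4 (within the scatter), the first step that isolates this position. At this read-out, the amide and the sulfonamide on this nitrogen therefore cannot be told apart. Nothing available here accounts for this result. As far as these compounds go, whether a longer acyl chain, a urea or the free amine at this nitrogen would read differently remains open. Also open, from the compounds shown here alone, is which structural difference sets compound 2 apart from the other three compounds.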